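This account rests on a few compounds, and the source may have more. Where it says the series, first, only, none or still open, it means among the compounds named here.

Measured compounds:
compound 1 `Nc1scc(CN2CCN(c3ccc(OC(F)(F)F)cc3)CC2)c1C(=O)c1ccc(Cl)cc1`, 0%
compound 2 `Nc1scc(CN2CCC(c3ccc(Cl)cc3)CC2)c1C(=O)c1ccc(Cl)cc1`, 0%

In an assay on CHO cells for displacement of a labelled ligand from adenosine receptor A1 (Homo sapiens), read by scintillation counting, with a stated time of 120 min, tested at 10 uM (on this read-out lower numbers stand for less inhibition and higher numbers for more inhibition at the one concentration tested (going by the name of the read-out)), compound 1 gives 0%. Its nearest neighbour on this read-out is compound 2, which in this assay gives 0%; compound 1 stands level with it at the digits shown, within the usual scatter. Compound 3 `Nc1scc(CN2CCN(c3ccc(F)c(Cl)c3)CC2)c1C(=O)c1ccc(Cl)cc1` is not yet measured. It differs from compound 1 in one place: 3-chloro-4-fluorophenyl in place of 4-(trifluoromethoxy)phenyl on an amine nitrogen in a ring. For the measured compounds named here, no measured pair shows the effect of such a change, so the expected step from compound 1 to compound 3, a number 3 percentage points higher from compound 1 to compound 3 (within the scatter), is none beyond the scatter. Compound 3 is therefore estimated at 3%, between 0% and 15%.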

Compound 3, a percentage reported as inhibition, at one concentration (the size of the read-out at that concentration, not a potency): 0%
Beside the measured number, compound 3's estimate is 3 percentage points above it; the measured number falls inside the stated range.
By their numbers in this assay, from the lowest: compounds 1, 2 and 3 (each within the scatter of the next).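

In this assay, placing 3-chloro-4-fluorophenyl in place of 4-(trifluoromethoxy)phenyl on the amine nitrogen in a ring gives no change at the digits printed from compound 1 to compound 3 (within the scatter), so this exchange of aryl groups at this position leaves the reading unmoved. Since neither compound shows any inhibition, the step says nothing about how either group would act on a compound with measurable inhibition. Nothing available explains the result. The compounds shown leave open whether a benzyl group, a pyridine ring or a carboxylic acid on the aryl ring at this nitrogen would give any inhibition.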